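The source may report more compounds than this note shows. Statements on the series, on what has been measured and on what is new or still open speak of the compounds shown alone.

Measured compounds:
- Compound 1 `Clc1ccc(CNc2nc(/C=C/c3ccco3)nc3ccsc23)cc1`: in a functional assay on L02 cells (Homo sapiens) for inhibition, read by Griess assay, with stated times of 1 h and 24 h (on this read-out higher numbers stand for weaker inhibition and lower numbers for stronger inhibition), compound 1 gives only a limit of the assay, > 1000000 nM.
- Compound 2 `COc1cc(/C=C/c2nc(N(C)C)c3sccc3n2)cc(OC)c1OC`: in this assay compound 2 likewise gives only a limit of the assay, > 1000000 nM.

Compound 2 stands at the same limit as compound 1, so no ranking between the two is possible; both share (the limit of > 1000000 nM in this assay, at which 2 of the 2 values shown sit).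

Compound 3 `COc1cc(/C=C/c2nc(OCc3ccccc3)c3sccc3n2)cc(OC)c1OC` is not yet measured. It differs from compound 2 in a single place: benzyloxy in place of dimethylamino on an aromatic carbon. For the measured compounds named here, with no measured step between any two compounds here, there is no anchor for how this kind of change moves the read-out. The expected step from compound 2 to compound 3 is therefore a number no higher from compound 2 to compound 3 (the limit leaves the size open), with a strong chance that only a limit is reported again. Compound 3 is estimated at 1000000 nM, within a range from 200000 nM to 5000000 nM.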

Compound 3, half-maximal inhibitory concentration: > 1000000 nM
Compound 3: a limit, no number; the forecaster's own chance of this, stated with the estimate: 80%; the middle value lies on the limit itself.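

No step can be read between compound 2 and compound 3, because both sit at the same limit of the assay: the limit of > 1000000 nM in this assay, at which 3 of the 3 values shown sit. The compounds shown leave open whether benzyloxy in place of dimethylamino changes inhibition at all in this assay; none gives an actual number.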